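Anilide variation on a shared core, checked for cytotoxicity

The compounds below may be only part of what the source reports. "The series", "measured", "known", "first", "only" and "open" are said of these compounds alone.

compound 1 `Cc1cccc(NC(=O)c2cccc(/C=C3\CC(=O)N(c4ccccc4)C3=O)c2)c1` — in an ADME assay on NCM460 cells (Homo sapiens) for cytotoxicity, read by MTT assay, with a stated time of 72 h (a higher number here means a weaker inhibitor, a lower number a stronger inhibitor), compound 1 gives > 100000 nM, a limit of the assay.
compound 2 `COc1ccc(NC(=O)c2cccc(/C=C3\CC(=O)N(c4ccccc4)C3=O)c2)c(C)c1` — in this assay compound 2 gives > 100000 nM, a limit of the assay.
compound 3 `COc1cc(NC(=O)c2cccc(/C=C3\CC(=O)N(c4ccccc4)C3=O)c2)cc(OC)c1OC` — in this assay compound 3 gives > 100000 nM, a limit of the assay.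

Compound 2 therefore stands only at a limit in this assay, as do both other measured compounds (the limit of > 100000 nM in this assay, at which 3 of the 3 values shown sit). Among the measured compounds shown here, the one step among them, a step that the two limits leave unreadable from compound 1 to compound 2, cannot be read from two limits. The change to compound 4 `CSc1cccc(NC(=O)c2cccc(/C=C3\CC(=O)N(c4ccccc4)C3=O)c2)c1` is 3-(methylsulfanyl)phenyl in place of 4-methoxy-2-methylphenyl on an amide-type nitrogen. No measured step bears readably on this change, and nothing in the shown values sets compound 4 apart. Compound 4 is therefore expected to give a limit as well, estimated at 100000 nM with a range from 50000 nM to 300000 nM. The expected step, a number no higher from compound 2 to compound 4 (the limit leaves the size open), is none beyond the scatter.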

Compound 4, half-maximal inhibitory concentration: > 100000 nM
Compound 4 gave a limit, no number; the forecaster's own chance of this, stated with the estimate: 85%; the middle value lies on the limit itself.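

Compound 4, like compounds 1 and 2, sits at a limit, so the steps from compound 1 and from compound 2 to compound 4 cannot be read: the limit of > 100000 nM in this assay, at which 4 of the 4 values shown sit.

The compounds shown leave open whether any of these anilide changes alters the result in this assay.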